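An Amino Chain Gains a Hydroxy Group

The source may hold more compounds than are shown below. What is called first, only, known or untested is meant among the compounds shown, and "the series" means these compounds.

Three compounds with a shared core differ only in the chain on sulfur. In a functional assay on HT cells (Homo sapiens) for antiproliferative activity, read by fluorescence, with a stated time of 72 h (on this read-out higher numbers stand for weaker inhibition of growth and lower numbers for stronger inhibition of growth), compound 1 (`CC(C)c1n[nH]c2c(NCc3ccc(-c4ccccn4)cc3)nc(SCC(C)(C)O)nc12`) gives 507 nM and compound 2 (`CC(C)c1n[nH]c2c(NCc3ccc(-c4ccccn4)cc3)nc(SC(CO)C(C)C)nc12`) gives 980 nM as values, a gap that reads a 1.9-fold higher number from compound 1 to compound 2 (0.29 log units; within the scatter) and does not separate them. Compound 3 (`CC(C)c1n[nH]c2c(NCc3ccc(-c4ccccn4)cc3)nc(SCC(C)(C)N)nc12`) gives 85 nM as the lowest of the three numbers.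

Compound 4 (`CC(C)c1n[nH]c2c(NCc3ccc(-c4ccccn4)cc3)nc(SC[C@H](O)CN)nc12`) keeps the core but alters the chain of compound 3: 2-amino-1-hydroxyethyl in place of 1-amino-1-methylethyl on a saturated chain carbon bound to a sulfur on the same carbon, so that 2-amino-2-methylpropyl becomes 3-amino-2-hydroxypropyl.

For the measured compounds named here, two measured steps bear on this. The first is a 6.0-fold lower number from compound 1 to compound 3 (0.78 log units; beyond the scatter) and the second is a 12-fold lower number from compound 2 to compound 3 (1.06 log units; beyond the scatter) on going to the amino chain. Going by the values given here, compound 4 retains the amino group but also carries a hydroxy group, and no measured compound holds both. A small rise is therefore expected, not the full size of those steps, and the expected change is a 1.8-fold higher number from compound 3 to compound 4 (0.25 log units; within the scatter) in this read-out. For compound 4 the estimated value is 150 nM with an expected range from 55 nM to 420 nM in this test.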

Compound 4, concentration for 50% growth inhibition: 63 nM
Compound 4: the middle estimate sits 2.4-fold (0.38 log units) above what was measured; the range from low to high includes it.
By their numbers in this assay, from the lowest: compounds 4 and 3 (each within the scatter of the next); then compounds 1 and 2 (each within the scatter of the next).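

In this assay, the 3-amino-2-hydroxypropyl chain and the 2-amino-2-methylpropyl chain on a sulfur do not separate, with a 1.3-fold lower number from compound 3 to compound 4 (0.13 log units; within the scatter), so this position accepts a chain that carries both the amino and the hydroxy group without a step beyond the scatter. Compound 4 also stands clear of both chains that carry a hydroxy group and no amino group, with an 8.0-fold lower number from compound 1 to compound 4 (0.91 log units; beyond the scatter) and a 16-fold lower number from compound 2 to compound 4 (1.19 log units; beyond the scatter), so all the listed steps from those two compounds to an amino chain lie beyond the scatter. Nothing available here explains these results.

The compounds shown leave open whether the opposite configuration at the stereocentre of compound 4 would give a similar number. They also leave open whether a dimethylamino group or a longer chain would hold up at this position.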